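The source may hold more compounds than are shown below. What is called first, only, known or untested is meant among the compounds shown, and "the series" means these compounds.

Working notes on the series.

Going by the values given here, the shared core is carried by compound 1 `NC1=NC2(CCOCC2)N(OCCCOc2cccc(Cl)c2)C(N)=N1`, which is the only member of the set with a numerical result. In a functional assay on HepG2 cells (Homo sapiens) for antiproliferative activity, read by MTT assay, with a stated time of 72 h (a lower number here means a stronger inhibitor, a higher number a weaker inhibitor), compound 1 gives 150 nM. Two further analogues have been made but give no number to compare against: compound 2 `Cc1ccc(OCCCON2C(N)=NC(N)=NC23CCOCC3)cc1`, for which the entry reads "not determined" (no result reported), and compound 3 `NC1=NC2(CCOCC2)N(OCCCOc2ccc(Cl)cc2Cl)C(N)=N1`, for which the entry reads "not determined" (no result reported). Compound 1 therefore stands alone on the numbers shown, and no step between two measured compounds is available to calibrate the effect of any change in this assay.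

The next compound, compound 4 `NC1=NC2(CCOCC2)N(OCCCOc2cccc(Br)c2)C(N)=N1`, differs from compound 1 in one place: bromo in place of chloro on an aromatic carbon. Bromo in place of chloro on an aromatic carbon is a small change in size and no change in donors, acceptors or charge, and with no measured step to point either way, no shift beyond the usual scatter is expected. The step from compound 1 to compound 4 is expected to be about no change at the digits printed from compound 1 to compound 4 (within the scatter). Compound 4 is thus estimated at 150 nM in this assay, with a range from 60 nM to 400 nM.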

Compound 4, half-maximal inhibitory concentration: 320 nM
Estimate against measurement, compound 4: 2.1-fold (0.33 log units) below; low and high end bracket the measured number.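

Bromo in place of chloro on an aromatic carbon gives a 2.1-fold higher number from compound 1 to compound 4 (0.33 log units; beyond the scatter) in this assay, the first measured step in the series. This position therefore responds to the exchange of one halogen for another, even though the counts of donors, acceptors and charge stay the same, and compound 4 at 320 nM remains active, though weaker than the chloro compound. Nothing measured in the material at hand bears on the reason for this step.

Going by these compounds, all of this rests on a single pair, so it remains open whether the order between 3-chlorophenyl and 3-bromophenyl extends to fluoro, methoxy or nitrile at the same place. Also open, on these data alone, is how a longer chain between the shared core and the aromatic ring would alter the result.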